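A chalcone chain swap: nitro in place of dimethylamino

The compounds below may be only part of what the source reports. "The series", "measured", "known", "first", "only" and "open" are said of these compounds alone.

For the measured compounds named here, compound 2 `COc1ccc(C(=O)/C=C/c2ccc(N(C)C)cc2)c2c1C=CC(C)(C)O2` is the only compound with a numerical result in a functional assay on HepG2 cells (Homo sapiens) for antiproliferative activity, read by MTT assay, with a stated time of 24 h (a lower number here means a stronger inhibitor, a higher number a weaker inhibitor), where compound 2 gives 730 nM. Compound 1 `COc1ccc(C(=O)/C=C/c2cccc(F)c2)c2c1C=CC(C)(C)O2` reaches only the limit of this assay, giving > 10000 nM. Going by the values given here, the one measured step, an at least 13-fold lower number from compound 1 to compound 2 (1.13 log units; beyond the scatter), is large, and it rests on a limit of > 10000 nM in this assay, at which 1 of the 2 values shown sits, rather than on two numbers.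

Compound 3 `COc1ccc(C(=O)/C=C/c2cccc([N+](=O)[O-])c2)c2c1C=CC(C)(C)O2` is not yet measured in this assay. Its difference from compound 2 is 3-nitrophenyl in place of 4-(dimethylamino)phenyl on a double-bonded chain carbon bound to a double-bonded chain carbon. Among the compounds with values here, the only measured step that bears on this change is the swap from the 3-fluorophenyl of compound 1 to the 4-(dimethylamino)phenyl of compound 2, which brought the large improvement an at least 13-fold lower number from compound 1 to compound 2 (1.13 log units; beyond the scatter). Compound 3 moves the chain back to a ring of the 3-substituted kind seen in compound 1, so the expected step of an 11-fold higher number from compound 2 to compound 3 (1.04 log units; beyond the scatter) from compound 2 to compound 3 is a sizeable loss in this assay. Compound 3 is therefore estimated at 8000 nM, within a range from 2000 nM to 30000 nM, with a real chance that only a limit is reported.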

Compound 3, half-maximal inhibitory concentration: 2830 nM
Compound 3: the middle estimate sits 2.8-fold (0.45 log units) above what was measured; the measured number falls inside the stated range.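

In this assay the change of nitro in place of fluoro on an aromatic carbon gives an at least 3.5-fold lower number from compound 1 to compound 3 (0.54 log units; beyond the scatter) and so shows that a ring of the 3-substituted kind can still give a measurable result at this place, with the group on that ring making a difference. The 4-(dimethylamino)phenyl ring still holds the better number, with a 3.9-fold higher number from compound 2 to compound 3 (0.59 log units; beyond the scatter) for the swap to 3-nitrophenyl, but this swap changes both the group and its place on the ring, so the step alone cannot say which of the two counts. The comparison with compound 1 also has a firm end at only one side, since the result for compound 1 is a limit and not a number: the limit of > 10000 nM in this assay, at which 1 of the 3 values shown sits.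

Still open, as far as these compounds go, is whether the dimethylamino group would keep its number on a 3-substituted ring, and whether nitro would do better on a 4-substituted one, the two pairings that would pull group and place apart. Also open, from the compounds shown here alone, is how a plain phenyl ring, a carboxylic acid or a longer amine such as diethylamino would read at this place.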